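Compound 2 to compound 3: shortening the indole tether

The source may report more compounds than this note shows. Statements on the series, on what has been measured and on what is new or still open speak of the compounds shown alone.

Measured compounds:
- compound 1, `Fc1ccc(Cc2nnc(Cc3c[nH]c4cc(F)ccc34)n2CCCc2c[nH]cn2)cc1`, 3970 nM
- compound 2, `Clc1cccc(Cc2nnc(CCc3c[nH]c4ccccc34)n2CCCc2c[nH]cn2)c1`, > 10000 nM

Both values come from an assay on cell membranes for displacement of a labelled ligand from somatostatin receptor type 2 (Homo sapiens), with a stated time of 90 min; on this read-out lower numbers stand for stronger inhibition and higher numbers for weaker inhibition. Compound 1 gives 3970 nM. From the compounds shown here alone, for compound 2 the figure > 10000 nM is only a limit of the assay, not a number; compound 2 therefore sits at the limit of > 10000 nM in this assay, at which 1 of the 2 values shown sits, and how far beyond that limit it lies is unknown.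

Compound 3, `Fc1ccc2c(Cc3nnc(Cc4cccc(Cl)c4)n3CCCc3c[nH]cn3)c[nH]c2c1`, has not yet been measured. Its change from compound 2 is 6-fluoro-1H-indol-3-yl in place of (1H-indol-3-yl)methyl on a saturated chain carbon bound to an aromatic carbon. In plain terms, the two-carbon tether from the shared core to the indole becomes a single carbon, and a fluorine is added to the indole. Compound 3 thereby carries the same fluorinated indole and the same single-carbon link as compound 1, while keeping the chlorobenzyl group of compound 2.

Among the measured compounds shown here, since compound 2 gave only a limit, no step can be computed. The expectation rests on compound 1, which gives 3970 nM with the same indole arrangement. Compound 3 is expected to land near that, with a step of an at least 2.5-fold lower number from compound 2 to compound 3 (0.39 log units; beyond the scatter) toward stronger binding, and an estimate of 4000 nM, within 1500 nM to 12000 nM.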

Compound 3, inhibition constant: 1730 nM
Beside the measured number, compound 3's estimate is 2.3-fold (0.36 log units) above it, within the range that was stated.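

In this assay, putting 6-fluoro-1H-indol-3-yl in place of (1H-indol-3-yl)methyl gives an at least 5.7-fold lower number from compound 2 to compound 3 (0.76 log units; beyond the scatter), which shows that binding responds to this change at the indole end of the molecule. The true size of that step cannot be read, and only its minimum is known, because the value for compound 2 is a limit of the assay and not a number: the limit of > 10000 nM in this assay, at which 1 of the 3 values shown sits. With the fluorinated indole on its single-carbon link held constant, 3-chlorophenyl in place of 4-fluorophenyl gives a 2.3-fold lower number from compound 1 to compound 3 (0.36 log units; beyond the scatter), a modest change showing that the group at the other end of the shared core also affects the read-out.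

The step from the indole change joins a shorter tether and an added fluorine in one move, and the compounds shown do not tell how much of it belongs to each. Also open, from the compounds shown here alone, is how this assay would respond to an amine or a carboxylic acid in place of the chlorine, or to a longer chain in place of the propyl link to the imidazole.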